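The compounds below may be only part of what the source reports. "The series", "measured", "known", "first", "only" and "open" are said of these compounds alone.

Working notes on a small set of compounds tested in a functional assay on the whole organism (strain albino) for inhibition, with Rattus norvegicus as the target, read by paw edema, with a stated time of 4 h, at a dose of 0.28 mmol/kg by the oral route; on this read-out lower numbers stand for less inhibition and higher numbers for more inhibition at the one dose given (going by the name of the read-out). Compound 1, `C=CCn1c(SCC(=O)c2ccccc2)nnc1-c1ccc(OC)c(OC)c1`, gives 72% in this assay. Compound 2, `C=CCn1c(SCC(=O)c2ccccc2)nnc1-c1ccc(OC)cc1`, gives 67% in this assay. The two structures differ by hydrogen in place of methoxy on an aromatic carbon, and the step is a number 5 percentage points lower from compound 1 to compound 2 (within the scatter). Compound 3, `CCn1c(SC/C(=N/O)c2ccccc2)nnc1-c1ccc(OC)cc1`, gives 78% in this assay; the difference between its core and the core of compound 1 is not broken down here. Compound 4, `CCn1c(SC/C(=N/O)c2ccccc2)nnc1-c1ccccc1`, is not yet measured. It differs from compound 3 by hydrogen in place of methoxy on an aromatic carbon. This is the same kind of change as that from compound 1 to compound 2, though not the same: in compound 1 the leaving methoxy is ortho to a methoxy group and meta to a large group, while in compound 3 it is para to a large group. Among the compounds with values here, because the only measured step of this kind, a number 5 percentage points lower from compound 1 to compound 2 (within the scatter), stays within the scatter, a step of similar size is expected, a number 6 percentage points lower from compound 3 to compound 4 (within the scatter). Compound 4 is accordingly estimated at 72%, with a likely range from 58% to 84%.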

Compound 4, a percentage reported as inhibition, in the whole organism at one dose (the size of the read-out at that dose, not a potency): 73%
The estimate for compound 4 lay 1 percentage points below the measured number, within the range that was stated.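

Replacing methoxy by hydrogen in this assay gives a number 5 percentage points lower from compound 3 to compound 4 (within the scatter), and the same change can now be compared on two cores: the same change on two cores in this assay, a number 5 percentage points lower (within the scatter) from compound 1 to compound 2 and a number 5 percentage points lower (within the scatter) from compound 3 to compound 4, 0 percentage points apart, within the scatter of two such steps. As far as two steps can tell, the change carries from the core of compound 1 to the core of compound 3 without a visible difference in size. Both steps lie within the scatter, however, so this does not show that methoxy matters to the read-out at all, and agreement between two small steps at a single dose says little about how a larger step would carry over.

The compounds shown leave open whether another group at the place para to a large group, such as a chlorine atom, an amine or a carboxylic acid, would give a step beyond the scatter. They also leave open the separate contributions of allyl against ethyl and of the ketone against the oxime, which differ together between the two cores.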